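Aryl amine sulfonamides: tert-butyl to phenyl swap

The source may report more compounds than this note shows. Statements on the series, on what has been measured and on what is new or still open speak of the compounds shown alone.

The series shares a bis(trifluoromethyl)benzenesulfonamide core linked through a chain to a benzylic amine. Compound 1 `O=S(=O)(NCCCNCc1cccc2ccccc12)c1cc(C(F)(F)F)cc(C(F)(F)F)c1` gives 2700 nM in a functional assay on BE(2)-C cells (Homo sapiens) for inhibition, read by MTT assay, with a stated time of 72 h; a lower number here means a stronger inhibitor of growth, a higher number a weaker inhibitor of growth. Compound 3 `O=S(=O)(NCCCNCc1ccc(Cl)cc1)c1cc(C(F)(F)F)cc(C(F)(F)F)c1` gives 2900 nM in this assay; the step of a 1.1-fold higher number from compound 1 to compound 3 (0.03 log units; within the scatter) shows that exchanging the aromatic group on the chain carbon bound to the amine nitrogen leaves the number essentially where it was. Compound 2 `CC(C)(C)c1ccc(CNCCNS(=O)(=O)c2cc(C(F)(F)F)cc(C(F)(F)F)c2)cc1` gives 14000 nM in this assay, the highest of the three numbers, standing beyond the scatter above both compound 3 and compound 1.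

Compound 4 `O=S(=O)(NCCNCc1ccc(-c2ccccc2)cc1)c1cc(C(F)(F)F)cc(C(F)(F)F)c1` is compound 2 with phenyl in place of tert-butyl on an aromatic carbon, para to a large group on the aromatic carbon. Within the data shown here, no measured step changes this position directly; the only aromatic-group variation on record, the step from compound 1 to compound 3, was within the scatter and sat on a different chain. Among the measured compounds shown here, because compound 2 gives 14000 nM and the one related change stayed within the scatter, compound 4 is expected near compound 2, with at most a small move and wide uncertainty. The expected step is a 1.6-fold lower number from compound 2 to compound 4 (0.19 log units; within the scatter). Compound 4 is estimated at 9000 nM, with a range from 3000 nM to 27000 nM, in this assay.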

Compound 4, concentration for 50% growth inhibition: 2700 nM
Compound 4: the middle estimate sits 3.3-fold (0.52 log units) above what was measured; the whole stated range lies above it.
By their numbers in this assay, from the lowest: compounds 1, 4 and 3 (each within the scatter of the next); then compound 2.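

In this assay the exchange of tert-butyl for phenyl gives a 5.2-fold lower number from compound 2 to compound 4 (0.71 log units; beyond the scatter) and so shows that this aromatic carbon, para to a large group, is sensitive to the group it carries. The earlier step of a 1.1-fold higher number from compound 1 to compound 3 (0.03 log units; within the scatter) gave no such sign, but it exchanged the whole aromatic group on a different chain, so it did not test this position and says little about it. The step is so far a bare observation on one pair, and no measurement at hand accounts for it.

Open, going by these compounds, is whether the lower number follows the aromatic ring itself or simply the larger group, which a cyclohexyl group or a pyridine ring on the same carbon would help to separate. Also open, on these data alone, is whether the phenyl gain carries over to a longer chain between the sulfonamide and the amine, and whether smaller groups such as methoxy or a lone fluorine on this carbon sit nearer to compound 2 or to compound 4 in this series.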